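Cytotoxicity series: a second methyl on the aryl group

The source may report more compounds than this note shows. Statements on the series, on what has been measured and on what is new or still open speak of the compounds shown alone.

Measured compounds:
compound 1 `Cc1cc(=O)n(-c2ccccc2OC(F)(F)F)nc1C(=O)Nc1ccc(Oc2ncnc3ccsc23)cc1`: 25000 nM
compound 2 `Cc1ccc(-n2nc(C(=O)Nc3ccc(Oc4ncnc5ccsc45)cc3)c(C)cc2=O)cc1`: 25000 nM

In a functional assay on HepG2 cells (Homo sapiens) for cytotoxicity, read by MTT assay, with a stated time of 72 h (a higher number here means a weaker inhibitor, a lower number a stronger inhibitor), compound 1 gives 25000 nM. In this assay compound 2 gives 25000 nM. Going by the values given here, the one step between them, no change at the digits printed from compound 1 to compound 2 (within the scatter), is the exchange of the aryl group on the aromatic nitrogen, and it moves nothing. Compound 2 therefore stands level with compound 1 on the numbers shown; neither can be called weaker or stronger than the other.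

Compound 3 `Cc1ccc(-n2nc(C(=O)Nc3ccc(Oc4ncnc5ccsc45)cc3)c(C)cc2=O)c(C)c1` is not yet measured. It differs from compound 2 by methyl in place of hydrogen on an aromatic carbon. Among the compounds with values here, the only step that bears on this part of the molecule is no change at the digits printed from compound 1 to compound 2 (within the scatter), which shows that a larger change of the same aryl group left the read-out unmoved. A single methyl added to that group is a smaller change still, and no step beyond the scatter is expected in this assay in either direction. For compound 3 the expected step is no change at the digits printed from compound 2 to compound 3 (within the scatter). The estimate for compound 3 is 25000 nM, with a range from 12000 nM to 50000 nM; the measured value is expected to land in that range.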

Compound 3, half-maximal inhibitory concentration: 17900 nM
Beside the measured number, compound 3's estimate is 1.4-fold (0.15 log units) above it, within the range that was stated.
By their numbers in this assay, from the lowest: compounds 3, 1 and 2 (each within the scatter of the next).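

In this assay, a methyl on an aromatic carbon ortho to a large group and meta to a methyl group gives a step within the scatter (a 1.4-fold lower number from compound 2 to compound 3 (0.15 log units; within the scatter)), so this position accepts the added methyl with no readable change in the number. The 2,4-dimethylphenyl group also reads within the scatter when set against the 2-(trifluoromethoxy)phenyl group (a 1.4-fold lower number from compound 1 to compound 3 (0.15 log units; within the scatter)), which puts all three aryl groups shown level in this read-out and adds a disubstituted example to the single earlier exchange. Nothing available speaks to what lies behind these small steps.

The compounds shown leave open whether an amine, a carboxylic acid or a longer chain on this aryl group would give a step beyond the scatter, as methyl and trifluoromethoxy substituents alone are represented here. They also leave open whether a change elsewhere, at the amide or in the shared core, would move the number in this assay, as all three compounds carry these parts unchanged.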